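Keto-oxazole series: varying the group on the oxazole

The compounds below may be only part of what the source reports. "The series", "measured", "known", "first", "only" and "open" are said of these compounds alone.

Measured so far:
compound 1 `Nc1cccc(-c2cnc(C(=O)CCCCCCc3ccccc3)o2)c1` gives 19 nM
compound 2 `O=C(CCCCCCc1ccccc1)c1ncc(-c2ccc(F)cc2)o1` gives 62 nM
compound 3 `NC(=O)c1ccc(-c2cnc(C(=O)CCCCCCc3ccccc3)o2)nc1` gives 1.2 nM

In an assay (Rattus norvegicus) for inhibition of Fatty-acid amide hydrolase 1 (Homo sapiens) (a higher number here means a weaker inhibitor, a lower number a stronger inhibitor), compound 3 stands lowest of the three numbers, with a 16-fold lower number from compound 1 to compound 3 (1.20 log units; beyond the scatter) and a 52-fold lower number from compound 2 to compound 3 (1.71 log units; beyond the scatter), both beyond the scatter. Compound 4 `CN(C)C(=O)c1cnc(C(=O)CCCCCCc2ccccc2)o1` alters the same position on the shared core: dimethylcarbamoyl in place of 5-carbamoylpyridin-2-yl on an aromatic carbon. Both measured steps at this carbon swap one ring for another; none removes the ring. They show only that this position moves the number a great deal. Among the measured compounds shown here, with no direct precedent, the change is expected to cost rather than gain, so for compound 4 a step of a 25-fold higher number from compound 3 to compound 4 (1.40 log units; beyond the scatter) toward a higher number is expected. Compound 4 is estimated at 30 nM, in the range 5 nM to 200 nM.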

Compound 4, inhibition constant: 2 nM
Beside the measured number, compound 4's estimate is 15-fold (1.18 log units) above it; the whole stated range lies above it.
By their numbers in this assay, from the lowest: compounds 3 and 4 (each within the scatter of the next); then compound 1; then compound 2.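

At this carbon of the shared core, a low number in this assay does not depend on an aromatic ring: replacing 5-carbamoylpyridin-2-yl with the ringless dimethylcarbamoyl gives a 1.7-fold higher number from compound 3 to compound 4 (0.22 log units; within the scatter). Dimethylcarbamoyl also improves on both other ring groups, with a 31-fold lower number from compound 2 to compound 4 (1.49 log units; beyond the scatter) and a 9.5-fold lower number from compound 1 to compound 4 (0.98 log units; beyond the scatter). Nothing available explains these results.

From the compounds shown here alone, whether the carbonyl of the dimethylcarbamoyl group matters remains open. A dimethylaminomethyl group or a carboxylic acid at this carbon would test this, as would an unsubstituted carbamoyl for the two methyl groups.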